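The source may report more compounds than this note shows. Statements on the series, on what has been measured and on what is new or still open speak of the compounds shown alone.

Of the compounds shown here, three sharing one core have been measured in an assay on HEK293 cells for displacement of a labelled ligand from corticotropin-releasing factor receptor 1 (Homo sapiens); on this read-out lower numbers stand for stronger inhibition and higher numbers for weaker inhibition. Compound 1 `CCN(CC1CC1)c1cc(C)nc2c(-c3ccc(Cl)cc3Cl)nn(C)c12` gives 4.4 nM, compound 2 `CCCCCN(CCCC)c1cc(C)nc2c(-c3ccc(Cl)cc3Cl)nn(C)c12` gives 0.9 nM, and compound 3 `CCCCN(c1cc(C)nc2c(-c3ccc(Cl)cc3Cl)nn(C)c12)C(CC)CC` gives 7 nM. Compound 3 thus stands at the highest number of the three; its gap to compound 1 lies within the scatter, while the step of a 7.8-fold higher number from compound 2 to compound 3 (0.89 log units; beyond the scatter) lies beyond it.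

Compound 4 `CCCCN(CCCOC)c1cc(C)nc2c(-c3ccc(Cl)cc3Cl)nn(C)c12` differs from compound 3 by one change: 3-methoxypropyl in place of pentan-3-yl on a nitrogen on an aromatic ring. Among the measured compounds shown here, the one measured step that bears on this place is the one from compound 2 to compound 3, where a branched pentan-3-yl in place of a straight pentyl raised the number by a modest but clear amount. For the measured compounds named here, compound 4 returns to a straight chain of the same length as pentyl, though with an oxygen in it; no measured pair tells what that oxygen does. The step of a 3.5-fold lower number from compound 3 to compound 4 (0.54 log units; beyond the scatter) is therefore expected to lower the number, roughly undoing the earlier rise. Compound 4 is estimated at 2 nM in this assay, within a range of 0.7 nM to 6 nM.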

Compound 4, inhibition constant: 18 nM
Compound 4: middle estimate off by 9.0-fold (0.95 log units), on the low side; measured number outside the range, above it.
By their numbers in this assay, from the lowest: compound 2; then compounds 1 and 3 (each within the scatter of the next); then compound 4.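

In this assay, a straight chain on this nitrogen does not by itself keep the number low: methoxy in place of ethyl at the end of the chain gives a 20-fold higher number from compound 2 to compound 4 (1.30 log units; beyond the scatter), a large step, whereas the branching step was the modest 7.8-fold higher number from compound 2 to compound 3 (0.89 log units; beyond the scatter). The 3-methoxypropyl chain also does not recover what pentan-3-yl lost, since replacing the branched group with it gives a 2.6-fold higher number from compound 3 to compound 4 (0.41 log units; beyond the scatter), so at this position the oxygen-bearing chain carries a clear cost against both all-carbon chains. Nothing available explains why this swap raises the number.

Going by these compounds, it remains open whether a hydroxyl or an amine at the chain end would behave like methoxy, or whether a longer chain carrying the same ether would. Also open, on these data alone, is whether methoxy has the same effect when the nitrogen carries the ethyl and cyclopropylmethyl groups of compound 1.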